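Replacing thiophen-2-yl with 2-phenylethenyl in compound 3

The compounds below may be only part of what the source reports. "The series", "measured", "known", "first", "only" and "open" are said of these compounds alone.

In a physicochemical assay for lipophilicity, measured as octanol-water partition (on this read-out higher numbers stand for higher lipophilicity and lower numbers for lower lipophilicity), compound 3 `O=C(NNc1ccnc2cc(Cl)ccc12)c1ccccc1/N=C/c1cccs1` gives 4.78. That is within the scatter of compound 2 `COc1ccc(/C=N/c2ccccc2C(=O)NNc2ccnc3cc(Cl)ccc23)cc1OC` at 4.97 and well short of compound 1 `O=C(NNc1ccnc2cc(Cl)ccc12)c1ccccc1/N=C/c1ccc(Cl)cc1Cl` at 6.22. In compound 4 `O=C(NNc1ccnc2cc(Cl)ccc12)c1ccccc1/N=C/C=C/c1ccccc1`, 2-phenylethenyl takes the place of thiophen-2-yl on the carbon with a double bond to nitrogen: 2-phenylethenyl in place of thiophen-2-yl on a carbon with a double bond to nitrogen. Three measured changes fall at this same place: a number 1.44 log units lower from compound 1 to compound 3 (beyond the scatter) and a number 1.25 log units lower from compound 1 to compound 2 (beyond the scatter), both large, and a number 0.19 log units lower from compound 2 to compound 3 (within the scatter), within the scatter. None of them brings in 2-phenylethenyl, so they bound the size only loosely. The expected change is a moderate rise beyond the scatter, smaller than the two large steps: a number 0.72 log units higher from compound 3 to compound 4 (beyond the scatter). For compound 4 the estimate is 5.5, with an expected range from 5 to 6.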

Compound 4, partition coefficient: 5.54
For compound 4 the middle estimate is 0.04 log units below the measured one; the range from low to high includes it.
By their numbers in this assay, from the lowest: compounds 3 and 2 (each within the scatter of the next); then compound 4; then compound 1.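

In this assay, within the data shown here, 2-phenylethenyl gives the first value at this position that lies clear of both earlier levels: it stands above the two neighbouring compounds (a number 0.76 log units higher from compound 3 to compound 4 (beyond the scatter) and a number 0.57 log units higher from compound 2 to compound 4 (beyond the scatter)) but under the 2,4-dichlorophenyl compound (a number 0.68 log units lower from compound 1 to compound 4 (beyond the scatter)). The four groups on the carbon with a double bond to nitrogen thus fall on three separate levels, with only compound 2 and compound 3 within the scatter of each other.

On these data alone, how an amine or a carboxylic acid at this place would read remains open. The compounds shown also come with no measurement that accounts for these steps.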